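Replacing the 1H-pyrrol-2-yl group of compound 3

This account rests on a few compounds, and the source may have more. Where it says the series, first, only, none or still open, it means among the compounds named here.

Of the compounds shown here, three sharing an amide side chain have been measured in an ADME assay (liver) for metabolic stability, with Liver microsome (Homo sapiens) as the target, using microsomes; a lower number here means that the compound disappears faster, a higher number that the compound lasts longer. There, compound 1 (`CCCc1nc2ccccn2c1C(=O)NCc1ccc(-c2ccccc2)cc1`) gives 0.373 h. Compound 2 (`Cc1nc2ccc(Cl)cn2c1C(=O)NCc1ccc(-c2ccccc2)cc1`) returns only a limit, > 2 h. Compound 3 (`CCc1nc2cc(Cl)ccn2c1C(=O)NCc1ccc(-c2ccc[nH]2)cc1`) also returns only a limit, > 2 h. Compound 3 therefore has no exact number and stands at the limit of > 2 h in this assay, at which 2 of the 3 values shown sit.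

Compound 4 (`CCc1nc2cc(Cl)ccn2c1C(=O)NCc1ccc(N2CC3CCCCC3C2)cc1`) differs from compound 3 in one place, on an aromatic carbon of a six-membered aromatic ring of carbon only, para to a large group. There, the 1H-pyrrol-2-yl group gives way to a larger group with one five-membered non-aromatic ring and one six-membered non-aromatic ring of carbon only: a group of 9 heavy atoms (8 carbon, 1 nitrogen; one five-membered non-aromatic ring with 1 hetero atom, one six-membered non-aromatic ring of carbon only) in place of a group of 5 heavy atoms (4 carbon, 1 nitrogen; one five-membered aromatic ring with 1 hetero atom), on an aromatic carbon.

Among the compounds with values here, no pair of measured compounds differs in one place alone, so the size of this change has not been measured directly. A fall in half-life beyond the usual scatter is nevertheless expected, as compound 1 at 0.373 h shows that a short half-life can occur among these compounds. The estimated change is an at least 2.5-fold lower number from compound 3 to compound 4 (0.39 log units; beyond the scatter). For compound 4 the expected half-life is 0.8 h, with an estimated range from 0.3 h to 2 h.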

Compound 4, half-life: 0.248 h
For compound 4 the middle estimate is 3.2-fold (0.51 log units) above the measured one, outside the stated range (below it).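

Within the data shown here, at this place, on an aromatic carbon of a six-membered aromatic ring of carbon only and para to a large group, a change can now be read on its own for the first time. In this assay, the 1H-pyrrol-2-yl group giving way to the larger group with one five-membered non-aromatic ring and one six-membered non-aromatic ring of carbon only gives an at least 8.0-fold lower number from compound 3 to compound 4 (0.90 log units; beyond the scatter). Among these compounds, this single exchange is therefore enough to move the half-life beyond the scatter, something the earlier compounds could not show, as none of them differed in one place alone. Compound 3 has only a limit here, so the step gives a lower bound on the size of the change: the limit of > 2 h in this assay, at which 2 of the 4 values shown sit.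

Which part of the exchange matters stays open, as the step alters size, the aromatic ring and the hydrogen-bond donor count all at once. From the compounds shown here alone, it is also open how a smaller group such as pyrrolidin-1-yl, or a morpholine, would behave at this same place on the core of compound 3.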